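The source may report more compounds than this note shows. Statements on the series, on what has been measured and on what is new or still open speak of the compounds shown alone.

Working notes on the series. The shared core of compound 1 `Cn1ncc2c(=O)n(-c3ccccc3)c(COc3cccc(F)c3)nc21` carries a phenyl on the ring nitrogen and, beside the carbonyl-bearing ring, a methyl on the pyrazole-type nitrogen; its side arm is an ether to 3-fluorophenylmethyl. In an assay on isolated protein for inhibition of retinal dehydrogenase 2 (Homo sapiens) (on this read-out lower numbers stand for stronger inhibition and higher numbers for weaker inhibition), compound 1 gives 1770 nM. Compound 2 `CC(Sc1nc2c(cnn2C)c(=O)n1-c1ccccc1)c1cccc(F)c1` replaces the ether arm with a thioether to 1-(3-fluorophenyl)ethyl, and in this assay compound 2 gives 110 nM. Compound 3 `CC(Sc1nc2nn(C3COC3)cc2c(=O)n1-c1ccccc1)c1ccccc1` keeps a thioether to 1-phenylethyl and carries an oxetane ring in place of the methyl; in this assay compound 3 gives 65 nM. Compound 2 thus stands second highest of the three numbers: its value and that of compound 3 lie within the scatter of each other, while compound 1 sits well beyond it on the weaker side.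

Compound 4 `CC(Sc1nc2c(cnn2C)c(=O)n1-c1ccccc1)c1cncnc1` differs from compound 2 in one place: pyrimidin-5-yl in place of 3-fluorophenyl on a saturated chain carbon bound to a saturated chain carbon and a sulfur. Among the compounds with values here, no measured pair in the set shows this change, so no step can be read off. A change of this kind on the carbon bound to sulfur is expected to cost little or nothing beyond the scatter, with a slight lean toward weaker inhibition, giving an expected step of a 2.3-fold higher number from compound 2 to compound 4 (0.36 log units; beyond the scatter). Compound 4 is therefore estimated at 250 nM in this assay, with a range from 80 nM to 800 nM.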

Compound 4, half-maximal inhibitory concentration: 380 nM
Beside the measured number, compound 4's estimate is 1.5-fold (0.18 log units) below it; low and high end bracket the measured number.
By their numbers in this assay, from the lowest: compounds 3 and 2 (each within the scatter of the next); then compound 4; then compound 1.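

Within the data shown here, this is the first one-place change measured, and it falls on the saturated chain carbon bound to a saturated chain carbon and a sulfur. In this assay, pyrimidin-5-yl in place of 3-fluorophenyl gives a 3.5-fold higher number from compound 2 to compound 4 (0.54 log units; beyond the scatter) and so shows that the ring at this position affects the read-out beyond the scatter, though only modestly and toward weaker inhibition. Nothing available bears on why this step arises.

Still open, as far as these compounds go, is how a pyridin-3-yl ring, a morpholine or a carboxylic acid would read at this position, and whether the step holds with the oxetane ring in place of the methyl. The effect of the thioether alone also stays unresolved, as compound 1 and compound 2 differ in more than one place.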